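From Compound 1 to Compound 3: One Group Exchanged

A few compounds are considered here, and "the series" means these few. Any claim that something is new, unique, unknown or untested is made for them only; others in the source may bear on it.

Compound 1 `CC(C)C(CC1C(=O)NC(=O)N1C)c1ccc(-c2ccc3cccc(F)c3c2)[nH]c1=O` gives 33600 nM
Compound 2 `CC(C)[C@H](C[C@H]1SC(=O)NC1=O)c1ccc(-c2ccc3cccc(F)c3c2)[nH]c1=O` gives 31200 nM

Within the data shown here, in a physicochemical assay for solubility, in phosphate buffer, measured as kinetic solubility (a lower number here means a less soluble compound, a higher number a more soluble compound), compound 1 stands within the scatter of compound 2, the only other compound measured. Compound 3 `CC(C)C(/C=C1/C(=O)NC(=O)N1C)c1ccc(-c2ccc3cccc(F)c3c2)[nH]c1=O` keeps the core of compound 1 but exchanges one group on a saturated chain carbon bound to an aromatic carbon and a saturated chain carbon (a group of 9 heavy atoms (5 carbon, 2 nitrogen, 2 oxygen; one five-membered non-aromatic ring with 2 hetero atoms) in place of a group of 9 heavy atoms (5 carbon, 2 nitrogen, 2 oxygen; one five-membered non-aromatic ring with 2 hetero atoms), on a saturated chain carbon bound to an aromatic carbon and a saturated chain carbon). The (3-methyl-2,5-dioxoimidazolidin-4-yl)methyl group leaves, and the entering group differs in its count of double bonds outside aromatic rings. Among the measured compounds shown here, no measured pair shows a step of this kind, so the data offer no direct guide. In this assay a small step is expected, leaning towards a lower number and staying within the scatter. The expected step is a 1.2-fold lower number from compound 1 to compound 3 (0.09 log units; within the scatter) by this estimate. For compound 3 the estimated value is 27000 nM with a range from 11000 nM to 50000 nM in this measurement.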

Compound 3, solubility: 34800 nM
Beside the measured number, compound 3's estimate is 1.3-fold (0.11 log units) below it, and the stated range covers the measured number.
By their numbers in this assay, from the lowest: compounds 2, 1 and 3 (each within the scatter of the next).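

In this assay, the exchange of the (3-methyl-2,5-dioxoimidazolidin-4-yl)methyl group for a group with one more double bond outside aromatic rings gives a 1.0-fold higher number from compound 1 to compound 3 (0.02 log units; within the scatter). Among these compounds, the earlier compounds offered no step in one place, so this is the first sign that this position can take this change with no step beyond the scatter. Nothing available accounts for this result. Still open, on these data alone, is how an amine, a carboxylic acid or a longer chain would fare on this saturated chain carbon.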